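The source may hold more compounds than are shown below. What is called first, only, known or untested is meant among the compounds shown, and "the series" means these compounds.

Measured so far:
- compound 1 `COc1cc(N2C(N)=C(C#N)C(c3ccc([N+](=O)[O-])cc3)C3=C2CC(C)(C)CC3=O)cc(OC)c1OC`: 10%
- compound 2 `COc1cc(N2C(N)=C(C#N)C(c3c(OC)ccc4ccccc34)C3=C2CC(C)(C)CC3=O)cc(OC)c1OC`: 0%

In a functional assay on Ehrlich cells (Mus musculus) for cytotoxicity, tested at 10 ug/mL (a lower number here means a weaker effect, a higher number a stronger effect of the compound at the concentration tested), compound 1 gives 10%, and compound 2 gives 0%. The step of a number 10 percentage points lower from compound 1 to compound 2 (within the scatter) is the only measured one in the set, and it lies within the scatter, so compound 2 and compound 1 are not separated by this assay; both sit at the low end of what the read-out can report.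

Compound 3 `COc1cc(N2C(N)=C(C#N)C(c3ccccc3O)C3=C2CC(C)(C)CC3=O)cc(OC)c1OC` is not yet measured. Its structural change relative to compound 2 is 2-hydroxyphenyl in place of 2-methoxynaphthalen-1-yl on a saturated ring carbon. Going by the values given here, this change touches the same saturated ring carbon that was varied in the one measured step, where the exchange of an aryl group left the activity unchanged within the scatter. Among the compounds with values here, with that single step as the only guide, and both measured numbers near the floor of the read-out, no shift beyond the scatter is expected, and the estimated step of a number 5 percentage points higher from compound 2 to compound 3 (within the scatter) reflects this. For compound 3 the expected value in this assay is 5%, within a range from 0% to 20%.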

Compound 3, a percentage reported as activity, at one concentration (the size of the read-out at that concentration, not a potency): 0%
Estimate against measurement, compound 3: 5 percentage points above; the range from low to high includes it.
By their numbers in this assay, from the lowest: compounds 2, 3 and 1 (each within the scatter of the next).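

In this assay, exchanging 2-methoxynaphthalen-1-yl for 2-hydroxyphenyl on the saturated ring carbon gives no change at the digits printed from compound 2 to compound 3 (within the scatter), even though this change removes one of the two aromatic rings and brings in a hydrogen-bond donor. At the same carbon, exchanging 4-nitrophenyl for 2-hydroxyphenyl gives a number 10 percentage points lower from compound 1 to compound 3 (within the scatter), so all three aryl groups now shown at this position remain unseparated by this assay at the concentration tested. Nothing available explains this lack of separation.

Still open, on these data alone, is whether a non-aromatic group on this carbon, such as a cyclohexyl ring or a butyl chain, or a dimethylamino group or carboxylic acid on the phenyl ring, would move the read-out beyond the scatter. Also open is what the rest of the core contributes, as all the compounds shown share the 3,4,5-trimethoxyphenyl group, the amino group and the cyano group, leaving replacements such as a benzyl group on the ring nitrogen untested in this series of comparisons.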